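A few compounds are considered here, and "the series" means these few. Any claim that something is new, unique, unknown or untested is made for them only; others in the source may bear on it.

Three ureas sharing one core have been measured in a functional assay on HepG2 cells (Homo sapiens) for antiproliferative activity, read by MTT assay, with a stated time of 48 h; a higher number here means a weaker inhibitor, a lower number a stronger inhibitor. Compound 1 `O=C(Nc1ccccc1)Nc1nnc(Sc2ncnc3scc(-c4ccncc4)c23)s1` gives 19400 nM. Compound 2 `Cc1ccc(NC(=O)Nc2nnc(Sc3ncnc4scc(-c5ccncc5)c34)s2)cc1Cl` gives 16000 nM. Compound 3 `O=C(Nc1ccc(Cl)cc1)Nc1nnc(Sc2ncnc3scc(-c4ccncc4)c23)s1` gives 28900 nM, the highest number of the three, though the gaps to the other two, a 1.5-fold higher number from compound 1 to compound 3 (0.17 log units; within the scatter) and a 1.8-fold higher number from compound 2 to compound 3 (0.26 log units; within the scatter), both lie within the scatter of the method. Compound 4 `COc1cccc(NC(=O)Nc2nnc(Sc3ncnc4scc(-c5ccncc5)c34)s2)c1` is the next step: 3-methoxyphenyl in place of 4-chlorophenyl on an amide-type nitrogen. Every aryl change tried so far at this position has left the number essentially where it was: a 1.2-fold lower number from compound 1 to compound 2 (0.08 log units; within the scatter), a 1.5-fold higher number from compound 1 to compound 3 (0.17 log units; within the scatter) and a 1.8-fold higher number from compound 2 to compound 3 (0.26 log units; within the scatter) are all within the scatter. Among the compounds with values here, a methoxy on the ring has not been tried, so no measured step speaks to it directly, but the three measured changes at the same place bear on it and none moved the number. Compound 4 is therefore expected to show no step beyond the scatter, a 1.3-fold lower number from compound 3 to compound 4 (0.12 log units; within the scatter), and its estimated value in this assay is 22000 nM, with a range from 9000 nM to 55000 nM.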

Compound 4, half-maximal inhibitory concentration: 28400 nM
Compound 4: middle estimate off by 1.3-fold (0.11 log units), on the low side; the range from low to high includes it.
By their numbers in this assay, from the lowest: compounds 2, 1, 4 and 3 (each within the scatter of the next).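

In this assay the 3-methoxyphenyl group, the only aryl group shown here with a hydrogen-bond acceptor, stays within the scatter of each of the three earlier groups on this amide-type nitrogen: a 1.0-fold lower number from compound 3 to compound 4 (0.01 log units; within the scatter) and a 1.8-fold higher number from compound 2 to compound 4 (0.25 log units; within the scatter) and a 1.5-fold higher number from compound 1 to compound 4 (0.17 log units; within the scatter). The four ureas therefore cannot be separated in this read-out, and the range of aryl groups that leaves the number within the scatter now extends from chloro-bearing rings to one bearing methoxy. Nothing measured here bears on the reason for this result.

From the compounds shown here alone, what a carboxylic acid or an amine on this ring would do to the number remains open, as does the effect of a cyclohexyl group in place of the ring. Going by these compounds, whether a change in the shared core would produce a step beyond the scatter also stays open.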